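Adding a Second Ethyl to the Amine of Compound 1

A few compounds are considered here, and "the series" means these few. Any claim that something is new, unique, unknown or untested is made for them only; others in the source may bear on it.

Going by the values given here, in a physicochemical assay for solubility, read by HPLC, measured as kinetic solubility, with a stated time of 24 h, at pH 6.5 (a lower number here means a less soluble compound, a higher number a more soluble compound), compound 1 `CCNCc1cc(C)cc(Nc2nc3ccccc3n2Cc2ccc(C(F)(F)F)cc2)c1O` gives 35000 nM, the higher of the two numbers measured so far. Its closest comparison, compound 2 `CCNCc1cc(Cl)cc(Nc2nc3ccccc3n2Cc2ccc(C(F)(F)F)cc2)c1O`, gives 12000 nM. That pair shows chloro in place of methyl on an aromatic carbon, a modest change of a 2.9-fold lower number from compound 1 to compound 2 (0.46 log units; beyond the scatter).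

Compound 3 `CCN(CC)Cc1cc(C)cc(Nc2nc3ccccc3n2Cc2ccc(C(F)(F)F)cc2)c1O` keeps the methyl of compound 1 and differs elsewhere, with ethyl in place of hydrogen on an amine nitrogen. The side chain thus goes from (ethylamino)methyl to (diethylamino)methyl. Among the compounds with values here, no measured step touches this nitrogen, so the chloro and methyl pair offers only a sense of scale, and the direction remains a judgement. With just that one modest step as a guide, only a small drift toward a lower number is expected in this assay, smaller than the measured step and not beyond the scatter. The expected change is a 1.8-fold lower number from compound 1 to compound 3 (0.24 log units; within the scatter). For compound 3 the estimated value is 20000 nM, with an expected range from 7000 nM to 50000 nM.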

Compound 3, solubility: < 5000 nM
Compound 3 was reported as a limit; the forecaster's own chance of this, stated with the estimate: 10%; middle value at least 4.0-fold (0.60 log units) away from the limit.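

In this assay, the amine nitrogen turns out to be a place where a single added group matters a great deal: ethyl in place of hydrogen gives an at least 7.0-fold lower number from compound 1 to compound 3 (0.84 log units; beyond the scatter). Going by these compounds alone, the one earlier step concerned a different place, an aromatic carbon, where chloro in place of methyl gave a 2.9-fold lower number from compound 1 to compound 2 (0.46 log units; beyond the scatter), so it said nothing about this nitrogen, and the new step is the larger of the two even as far as it can be read. The value of compound 3 is a limit and not a number: the limit of < 5000 nM in this assay, at which 1 of the 3 values shown sits.

Going by these compounds, the real size of the drop therefore stays open, since the step marks only the least it can be, and a single change at the nitrogen cannot show whether the number falls gradually or abruptly as the group there grows. Also open, on these data alone, are whether a smaller group such as methyl, a longer chain such as propyl, or a ring amine such as pyrrolidine would behave in the same way at this nitrogen, and whether a second ethyl would have a similar effect on compound 2, which carries chloro in place of methyl.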